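The source may hold more compounds than are shown below. What is called first, only, known or untested is meant among the compounds shown, and "the series" means these compounds.

Measured so far in a functional assay on Jurkat cells (Homo sapiens) for antiproliferative activity, read by MTT assay, with a stated time of 48 h; on this read-out lower numbers stand for stronger inhibition and higher numbers for weaker inhibition:

- compound 1 `CCCCc1ccc2c(c1)C(=O)C(=O)N2`: > 10000 nM (a limit, not a number)
- compound 2 `COC(=O)/C=C/c1ccc2c(c1)C(=O)C(=O)N2`: 200 nM

Among the measured compounds shown here, compound 2, at 200 nM, holds the only number. For the measured compounds named here, the sole other reading is the limit of compound 1, so there is no second number to rank compound 2 against.

Compound 3 `CCN1C(=O)C(=O)c2cc(/C=C/C(=O)OC)ccc21` keeps the side chain of compound 2 and changes one place: ethyl in place of hydrogen on an amide-type nitrogen in a ring. Going by the values given here, no measured pair tests a change at this nitrogen, so the expectation has no direct support and rests on compound 2 at 200 nM as its only anchor. In this assay, a step no larger than the usual scatter is expected, with a slight lean towards stronger inhibition. The estimate is thus a small one, a 1.3-fold lower number from compound 2 to compound 3 (0.12 log units; within the scatter), and it is expected to stay within the scatter. The estimated value for compound 3 is 150 nM, with an expected range of 40 nM to 600 nM.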

Compound 3, half-maximal inhibitory concentration: 200 nM
Compound 3: the middle estimate sits 1.3-fold (0.12 log units) below what was measured, within the range that was stated.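

In this assay ethyl in place of hydrogen on an amide-type nitrogen in a ring gives no change at the digits printed from compound 2 to compound 3 (within the scatter) and so the amide hydrogen is not required for this read-out, at least with the side chain of compound 2 in place. Among the compounds shown here, this is the first measured pair that tests this nitrogen, and it shows that the position accepts ethyl without a step beyond the scatter, a statement that rests on this one pair alone. No measured information here bears on the cause of so small a step.

From the compounds shown here alone, how far this tolerance extends on the nitrogen stays open, since a longer chain such as butyl, a benzyl group, or a chain ending in an amine or a carboxylic acid would show whether the flat step holds beyond ethyl. Also open, going by these compounds, is whether the same nitrogen change behaves alike with a different side chain, for example with a carboxylic acid in place of the methyl ester.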